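The compounds below may be only part of what the source reports. "The series", "measured", "known", "first", "only" and "open" are said of these compounds alone.

Of the compounds shown here, two have so far been measured in a functional assay on WI-38 VA13 cells (Homo sapiens) for cytotoxicity; on this read-out lower numbers stand for an effect already at smaller amounts and higher numbers for an effect only at larger amounts of compound. Compound 1 `Cc1ccc(F)cc1S(=O)(=O)Nc1ccc2nc(NC(=O)C3CCCCC3)sc2c1` gives 0.7 ug/mL in this assay. Compound 2 `O=C(Nc1ccc2nc(NC(=O)C3CC3)sc2c1)c1c(Cl)cccc1Cl` gives 0.013 ug/mL in this assay, the lower of the two numbers, and its gap to compound 1 lies well beyond the usual scatter. Compound 3 `CCCCCNc1nc2ccc(NC(=O)c3c(Cl)cccc3Cl)cc2s1` has not yet been measured. It differs from compound 2 in one place: pentyl in place of cyclopropylcarbonyl on a nitrogen on an aromatic ring. Among the measured compounds shown here, no measured pair shows this kind of change, so the expectation rests on compound 2 alone. Compound 3 is expected to give a higher number, a step of a 12-fold higher number from compound 2 to compound 3 (1.06 log units; beyond the scatter), with an estimate of 0.15 ug/mL and a range from 0.03 ug/mL to 1 ug/mL.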

Compound 3, half-maximal effective concentration: 0.27 ug/mL
Beside the measured number, compound 3's estimate is 1.8-fold (0.26 log units) below it, within the range that was stated.
By their numbers in this assay, from the lowest: compound 2; then compound 3; then compound 1.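

Replacing cyclopropylcarbonyl with pentyl on this nitrogen gives a 21-fold higher number from compound 2 to compound 3 (1.32 log units; beyond the scatter) in this assay, so the position is sensitive to what it carries, even though both groups have the same number of heavy atoms. The change removes the ring and the carbonyl together, so their separate contributions cannot be told apart. No measurement here explains the step.

A pentanoyl group would keep the carbonyl without the ring, while a cyclopropylmethyl group would keep the ring without the carbonyl. As far as these compounds go, how either would compare remains open.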